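Nitrofuranyl chalcones: cytotoxicity on Vero cells

The compounds below may be only part of what the source reports. "The series", "measured", "known", "first", "only" and "open" are said of these compounds alone.

Compound 1 `Cc1ccc(C(=O)/C=C/c2ccc([N+](=O)[O-])o2)cc1`: 439000 nM
Compound 2 `O=C(/C=C/c1ccc([N+](=O)[O-])o1)c1cccs1`: 742000 nM
Compound 3 `O=C(/C=C/c1ccc([N+](=O)[O-])o1)c1cc2ccccc2oc1=O`: 360000 nM

In a toxicity assay on Vero cells (Chlorocebus sabaeus) for cytotoxicity (a lower number here means that less compound is tolerated, a higher number that more compound is tolerated), compound 1 gives 439000 nM, the second highest of the three numbers. Compound 3 gives 360000 nM and compound 2 gives 742000 nM; both gaps to compound 1 lie within the scatter, so the three compounds cannot be told apart here.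

Compound 4 `O=C(/C=C/c1ccc([N+](=O)[O-])o1)c1ccc(OCc2ccccc2)cc1` is not yet measured in this assay. It differs from compound 1 by benzyloxy in place of methyl on an aromatic carbon. Going by the values given here, no pair measured so far isolates this change, and the three aryl ketones differ widely in the aryl part without the numbers moving beyond the scatter. Compound 4 is therefore expected to stay close to compound 1, with a step from a 1.3-fold lower number from compound 1 to compound 4 (0.10 log units; within the scatter) that is not beyond the scatter. The estimate for compound 4 is 350000 nM, in the range 120000 nM to 900000 nM.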

Compound 4, half-maximal cytotoxic concentration: 515000 nM
Estimate against measurement, compound 4: 1.5-fold (0.17 log units) below; measured number inside the range.
By their numbers in this assay, from the lowest: compounds 3, 1, 4 and 2 (each within the scatter of the next, the first and the last beyond it).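

In this assay, benzyloxy in place of methyl on an aromatic carbon, para to a large group, gives a 1.2-fold higher number from compound 1 to compound 4 (0.07 log units; within the scatter), the only step shown that isolates a change at this position. This position therefore carries a much larger group with an added aromatic ring, and the number cannot be told apart from that of the methyl compound. No measurement shown gives a reason for this result.

Open, from the compounds shown here alone, is whether an amine or a carboxylic acid at this position would also stay within the scatter. Also open, going by these compounds, is whether a longer alkyl chain or a small alkoxy group such as methoxy would do the same.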